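Removing a methoxy from compound 1: what to expect

A few compounds are considered here, and "the series" means these few. Any claim that something is new, unique, unknown or untested is made for them only; others in the source may bear on it.

Compound 1, `COc1cc(OC)cc(-c2nc3cc(C(F)(F)F)ccc3[nH]2)c1`, gives 19000 nM in an ADME assay on MT4 cells (Homo sapiens) for cytotoxicity, read by MTT assay, with a stated time of 96 h; a higher number here means that more compound is tolerated, a lower number that less compound is tolerated.
Compound 2, `COc1ccc(-c2nc3cc(C(C)=O)ccc3[nH]2)c(OC)c1OC`, gives > 100000 nM in this assay.
Compound 3, `COc1cc(-c2nc3cc(C(F)(F)F)ccc3[nH]2)cc(OC)c1OC`, gives 4000 nM in this assay.

All three share one core, carrying a benzene ring with methoxy groups. The value for compound 2 is a limit of this assay, not a number, as described by the limit of > 100000 nM in this assay, at which 1 of the 3 values shown sits. Among the two numbers, compound 1 stands highest; its nearest neighbour is compound 3, and the step from one to the other, a 4.8-fold lower number from compound 1 to compound 3 (0.68 log units; beyond the scatter), is beyond the scatter.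

Compound 4, `COc1cccc(-c2nc3cc(C(F)(F)F)ccc3[nH]2)c1`, has not yet been measured. It differs from compound 1 as follows: hydrogen in place of methoxy on an aromatic carbon. Among the measured compounds shown here, this is the reverse of the only measured change of the same kind, which added a methoxy to the same ring. For the measured compounds named here, that step lowered the number in this assay by a modest amount, so taking a methoxy away is expected to move the number in the opposite direction, upward, by a similar or somewhat smaller amount, though only one step supports this and compound 2 offers no number to compare. The expected step from compound 1 is a 1.8-fold higher number from compound 1 to compound 4 (0.27 log units; within the scatter). For compound 4 the estimated value in this assay is 35000 nM, expected to fall between 12000 nM and 90000 nM.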

Compound 4, half-maximal cytotoxic concentration: 19000 nM
Compound 4: the middle estimate sits 1.8-fold (0.27 log units) above what was measured; the measured number falls inside the stated range.
By their numbers in this assay, from the lowest: compound 3; then compounds 1 and 4 (each within the scatter of the next). At a limit, above all of these: compound 2.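

In this assay, replacing the methoxy that sits meta to a large group with hydrogen gives no change at the digits printed from compound 1 to compound 4 (within the scatter), so this methoxy can go without any visible effect on the read-out. The earlier compounds shown here showed only a change in the other direction, a 4.8-fold lower number from compound 1 to compound 3 (0.68 log units; beyond the scatter), and it was natural to read that step as a general effect of methoxy count; the new step shows that adding a methoxy and removing one from compound 1 are not mirror images, and that on this ring the number of methoxy groups alone does not set the value. Nothing in the data shown bears on why this methoxy makes no difference while the added one does.

Still open, going by these compounds, is whether this place accepts only hydrogen and methoxy, or whether a larger or different group, such as a hydroxyl, an amine or a carboxylic acid, would also leave the number unmoved. Also open, on these data alone, is what happens when the last methoxy of compound 4 is replaced by hydrogen as well, leaving that ring with no substituent.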